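The source may hold more compounds than are shown below. What is called first, only, known or untested is meant among the compounds shown, and "the series" means these compounds.

Compound 1, `CCc1ccc(-c2ccc(NC3=CC(=O)c4ncncc4C3=O)cc2)cc1`, gives 1200 nM.
Compound 2, `Cc1ccc(-c2ccc(NC3=CC(=O)c4ncncc4C3=O)cc2F)cc1`, gives 4800 nM.
Compound 3, `O=C1C=CC(=O)c2ncncc21`, gives 18000 nM.

These numbers come from a functional assay on PANC-1 cells (Homo sapiens) for cytotoxicity, read by MTT assay, with a stated time of 72 h; on this read-out lower numbers stand for stronger inhibition and higher numbers for weaker inhibition. Compound 1 stands lowest of the three: compound 2 lies beyond the scatter above it, and compound 3, the shared core carrying no attached group, lies furthest above it. Compound 4, `O=C1C(Nc2ccc(-c3ccc(F)cc3)cc2)=CC(=O)c2ncncc21`, is built from compound 1 by one change: fluoro in place of ethyl on an aromatic carbon. The altered position sits on an aromatic carbon of a six-membered aromatic ring of carbon only, para to a large group. Among the measured compounds shown here, no measured pair here shows what this kind of swap does, so the expectation rests on compound 1 alone. A modest weakening is expected, with the step from compound 1 to compound 4 estimated at a 1.7-fold higher number from compound 1 to compound 4 (0.22 log units; within the scatter), near the edge of the scatter. Compound 4 is therefore expected to give about 2000 nM, within a range of 800 nM to 5000 nM.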

Compound 4, half-maximal inhibitory concentration: 3200 nM
For compound 4 the middle estimate is 1.6-fold (0.20 log units) below the measured one; the measured number falls inside the stated range.
By their numbers in this assay, from the lowest: compound 1; then compounds 4 and 2 (each within the scatter of the next); then compound 3.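

Replacing ethyl with fluoro on this aromatic carbon gives a 2.7-fold higher number from compound 1 to compound 4 (0.43 log units; beyond the scatter) and so a modest but real loss of strength, which shows that the group at this position affects the result. Of these two groups, ethyl gives the lower number. Nothing available here explains this difference.

As far as these compounds go, whether a longer chain such as propyl, an amine or a carboxylic acid at this position would lower or raise the number remains open. A single pair also cannot show whether the same swap would have a similar effect elsewhere on the molecule.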